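A few compounds are considered here, and "the series" means these few. Any claim that something is new, unique, unknown or untested is made for them only; others in the source may bear on it.

The measured compounds:

Compound 1, `CC(=O)OCC(CCn1cc(C#Cc2cc(F)cc(F)c2)c(=O)n(C(=O)c2ccccc2)c1=O)COC(C)=O`: 28900 nM
Compound 2, `CC(=O)OCC(CCn1cc(C#Cc2ccc(Br)cc2)c(=O)n(C(=O)c2ccccc2)c1=O)COC(C)=O`: 28900 nM
Compound 3, `O=c1[nH]c(=O)n(CCC(CO)CO)cc1C#Cc1cc(F)cc(F)c1`: 63100 nM

All three were tested in a functional assay on MCF7 cells (Homo sapiens) for antiproliferative activity, read by MTT assay, with a stated time of 72 h; on this read-out lower numbers stand for stronger inhibition and higher numbers for weaker inhibition. Compound 1 and compound 2 share one core and differ in a single group, namely (4-bromophenyl in place of 3,5-difluorophenyl on a triple-bonded carbon). This change gave no change at the digits printed from compound 1 to compound 2 (within the scatter), so the two values cannot be told apart. Compound 3 is built on another core, and how its core differs from that of compound 1 is not broken down here. Compound 3 gives the highest of the three numbers, and its gaps to compound 1 and to compound 2 both lie beyond the scatter.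

Compound 4, `O=c1[nH]c(=O)n(CCC(CO)CO)cc1C#Cc1ccc(Br)cc1`, has not yet been measured in this assay. It differs from compound 3 by 4-bromophenyl in place of 3,5-difluorophenyl on a triple-bonded carbon. The place is described in the same words for both pairs, so this is the same change as that seen between compound 1 and compound 2. The step expected is a 1.1-fold lower number from compound 3 to compound 4 (0.02 log units; within the scatter), because no change at the digits printed from compound 1 to compound 2 (within the scatter) was seen for the like change, so compound 4 should stay close to compound 3. Compound 4 is therefore expected to give 60000 nM, with a likely range from 30000 nM to 120000 nM.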

Compound 4, half-maximal inhibitory concentration: 46000 nM
For compound 4 the middle estimate is 1.3-fold (0.12 log units) above the measured one; measured number inside the range.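

In this assay, putting 4-bromophenyl in place of 3,5-difluorophenyl on the triple-bonded carbon gave a 1.4-fold lower number from compound 3 to compound 4 (0.14 log units; within the scatter). Set beside the earlier step, the change carries from one core to the other with no difference that can be told apart: the same change on two cores in this assay, no change at the digits printed (within the scatter) from compound 1 to compound 2 and a 1.4-fold lower number (0.14 log units; within the scatter) from compound 3 to compound 4, 1.4-fold (0.14 log units) apart, within the scatter of two such steps. This shows that, on these two cores, the exchange of these two groups leaves the number within the scatter, but it rests on a single pair per core and does not show that the change would stay as small on any other core or for any other pair of groups.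

The compounds shown leave open whether an unsubstituted phenyl, or an amine or a carboxylic acid on the aromatic ring, would move the number beyond the scatter. They also leave open what a longer chain in place of the one bearing the two hydroxymethyl or acetoxymethyl arms would do.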